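A few compounds are considered here, and "the series" means these few. Any claim that something is new, unique, unknown or untested is made for them only; others in the source may bear on it.

The measured compounds:

Compound 1 `CCCCCCCn1cc(COC[C@@H]2OC[C@H](N)[C@@H]2O)nn1`, which in a functional assay on MGC-803 cells (Homo sapiens) for antiproliferative activity, read by MTT assay, with a stated time of 48 h (a higher number here means a weaker inhibitor, a lower number a stronger inhibitor), reaches only the limit > 128000 nM.
Compound 2 `CCCCCCCCn1cc(COC[C@@H]2OC[C@H](N)[C@@H]2O)nn1`, which in this assay gives 70400 nM.
Compound 3 `CCCCCCCCCn1cc(COC[C@@H]2OC[C@H](N)[C@H]2O)nn1`, which in this assay reaches only the limit > 128000 nM.

From compound 1 to compound 2 the change is methyl in place of hydrogen on a saturated chain carbon, seven bonds along the chain from an aromatic nitrogen, and the step is an at least 1.8-fold lower number from compound 1 to compound 2 (0.25 log units; that floor lies within the scatter). Its floor is set by the limit of > 128000 nM in this assay, at which 2 of the 3 values shown sit. Compound 3 shares the same kind of change with the unmeasured compound 4 `CCCCCCCCCCn1cc(COC[C@@H]2OC[C@H](N)[C@H]2O)nn1`: methyl in place of hydrogen on a saturated chain carbon, nine bonds along the chain from an aromatic nitrogen. The place differs: seven bonds along the chain from the aromatic nitrogen in the first pair, nine bonds in the second, so it is the same kind of change, not the same. The difference between the cores of compound 1 and compound 3 is not broken down here.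

For compound 3 only a limit is known, and the earlier step barely clears its own floor, so compound 4 is expected to stay weak, with a step of an at least 1.2-fold lower number from compound 3 to compound 4 (0.10 log units; that floor lies within the scatter) estimated against the measured value of compound 3. The estimate for compound 4 is 100000 nM, between 40000 nM and 128000 nM.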

Compound 4, half-maximal inhibitory concentration: 57400 nM
Compound 4: middle estimate off by 1.7-fold (0.24 log units), on the high side, and the stated range covers the measured number.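

In this assay, methyl in place of hydrogen on a saturated chain carbon, nine bonds along the chain from an aromatic nitrogen, gives an at least 2.2-fold lower number from compound 3 to compound 4 (0.34 log units; beyond the scatter). This shows that the same kind of change, made one place further along the chain and on a different core, again goes with a lower number, although only the newer floor clears the scatter. It does not show that the change carries over with the same size from one core to the other, and both steps are known only as floors: the same change on two cores in this assay, an at least 1.8-fold lower number (0.25 log units; that floor lies within the scatter) from compound 1 to compound 2 and an at least 2.2-fold lower number (0.34 log units; beyond the scatter) from compound 3 to compound 4; the limit leaves it open whether they differ. Neither step can be pinned down any further, as each one starts from an assay limit: the limit of > 128000 nM in this assay, at which 2 of the 4 values shown sit.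

The compounds shown leave open whether a longer chain on the core of compound 4 would lower the number further, and whether the same chain would behave alike on both cores. They also leave open what an amine or a hydroxyl at the far end of the chain would do in place of the methyl.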